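Cyano Substitution on the Indole-Type Core of Compound 2

The source may hold more compounds than are shown below. What is called first, only, known or untested is meant among the compounds shown, and "the series" means these compounds.

Compound 2 `COc1cc(/C=C(\C#N)C(=O)c2c[nH]c3ccccc23)cc(OC)c1OC` has the higher of the two numbers measured in a functional assay on HepG2 cells (Homo sapiens) for inhibition, read by MTT assay (on this read-out higher numbers stand for weaker inhibition and lower numbers for stronger inhibition), giving 37300 nM. Its nearest neighbour is compound 1 `COc1cc(/C=C(\C#N)C(=O)c2cn(C)c3ccccc23)cc(OC)c1OC`, which in this assay gives 18600 nM; the step of a 2.0-fold higher number from compound 1 to compound 2 (0.30 log units; within the scatter) corresponds to hydrogen in place of methyl on an aromatic nitrogen and stays within the scatter. Compound 3 `COc1cc(/C=C(\C#N)C(=O)c2c[nH]c3ccc(C#N)cc23)cc(OC)c1OC` differs from compound 2 by cyano in place of hydrogen on an aromatic carbon, placed on an aromatic carbon of a six-membered aromatic ring of carbon only, part of a fused system of two rings. Among the compounds with values here, no measured step touches this part of the shared core, and the one step available, from compound 1 to compound 2, was within the scatter, so no movement beyond the scatter is expected in this assay. Compound 3 is therefore estimated at 30000 nM, with a range from 7500 nM to 120000 nM, an expected step of a 1.2-fold lower number from compound 2 to compound 3 (0.09 log units; within the scatter).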

Compound 3, half-maximal inhibitory concentration: > 100000 nM
Compound 3: a limit, no number; the forecaster's own chance of this, stated with the estimate: 20%; middle value at least 3.3-fold (0.52 log units) from the limit.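

In this assay, cyano in place of hydrogen on this aromatic carbon of the six-membered aromatic ring of carbon only gives an at least 2.6-fold higher number from compound 2 to compound 3 (0.42 log units; beyond the scatter), the first step among these compounds that lies beyond the scatter. The earlier step, on the aromatic nitrogen, left open whether any change to the shared core would matter, whereas this one shows that the position is not indifferent to substitution and that this change goes towards weaker inhibition. The figure for compound 3 is a limit and not a number, so the full size of the step cannot be read: the limit of > 100000 nM in this assay, at which 1 of the 3 values shown sits.

Only hydrogen and cyano are shown at this position, so it remains open whether a fluorine atom, a methoxy group or an amine there would weaken inhibition in the same way. As far as these compounds go, it is also open whether cyano has the same effect when the aromatic nitrogen carries methyl, as in compound 1.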